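The source may hold more compounds than are shown below. What is called first, only, known or untested is meant among the compounds shown, and "the series" means these compounds.

Compound 1 `CN(C)C(=O)c1cc2cnc(Nc3ccc(C(=O)NCCCCCN=C=S)cc3)nc2n1C1CCCC1` is the reference point here. Among the compounds with values here, in a functional assay on A549 cells (Homo sapiens) for inhibition, read by CCK-8 assay, with a stated time of 72 h, tested at 10 uM (on this read-out higher numbers stand for a stronger effect at the one concentration tested and lower numbers for a weaker effect), compound 1 gives 100%, the higher of the two numbers measured so far. Within the data shown here, its only measured neighbour is compound 2 `CN(C)C(=O)c1cc2cnc(Nc3ccc(C(=O)NCCCCCN=C=S)cc3O)nc2n1C1CCCC1`, which carries a hydroxy in place of hydrogen on an aromatic carbon; in the same read-out compound 2 gives 30.7%, and the step of a number 69.3 percentage points lower from compound 1 to compound 2 (beyond the scatter) is large and beyond the scatter. Compound 3 `CN(C)C(=O)c1cc2cnc(Nc3ccc(N=C=S)cc3)nc2n1C1CCCC1` has not yet been measured. It differs from compound 1 in another way: a group of 3 heavy atoms (1 carbon, 1 nitrogen, 1 sulfur; no ring) in place of a group of 11 heavy atoms (7 carbon, 2 nitrogen, 1 oxygen, 1 sulfur; no ring), on an aromatic carbon. The smaller group that enters sits directly on the ring where the larger group used to be attached. Among the measured compounds shown here, the one measured step, from compound 1 to compound 2, changes a different part of the molecule and therefore gives no direct guide to this exchange; it only shows that a modest change on this ring can cost a lot. Since the shared core and a related terminal group are kept, compound 3 is expected to remain active but possibly short of compound 1. The expected step is a number 30 percentage points lower from compound 1 to compound 3 (beyond the scatter). The estimate for compound 3 is 70%, with a range from 30% to 100%.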

Compound 3, a percentage reported as inhibition, at one concentration (the size of the read-out at that concentration, not a potency): 97.9%
Estimate against measurement, compound 3: 27.9 percentage points below; the measured number falls inside the stated range.
By their numbers in this assay, from the lowest: compound 2; then compounds 3 and 1 (each within the scatter of the next).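

In this assay, replacing the group of 11 heavy atoms with the much smaller isothiocyanate group of 3 heavy atoms, placed directly on the aromatic carbon, gives a number 2.1 percentage points lower from compound 1 to compound 3 (within the scatter). Within the data shown here, at this position, then, the amide and the long chain that separate the isothiocyanate from the ring can be removed without a measurable loss at the one concentration tested, so a large exchange here need not cost activity, unlike the single hydroxy exchange elsewhere on this ring, which gives a number 69.3 percentage points lower from compound 1 to compound 2 (beyond the scatter). No measurement shown explains why the shorter group holds up so well.

This read-out gives the size of the effect at a single concentration rather than a potency. Compound 1 and compound 3 could still separate at lower concentrations, and the data shown cannot settle that. From the compounds shown here alone, it also remains open what a chain of intermediate length ending in the same isothiocyanate would give, and whether the isothiocyanate itself matters, which an amine or a carboxylic acid at the same place would test.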